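The source may hold more compounds than are shown below. What is called first, only, known or untested is meant among the compounds shown, and "the series" means these compounds.

Measured compounds, minimum effective dose:

compound 1 `CC1(c2ccccc2)CC(=O)N(CC(=O)N2CCOCC2)C1=O`: 300 mg/kg
compound 2 `CC1(c2ccccc2)CC(=O)N(CC(=O)N2CCN(c3cccc(Cl)c3)CC2)C1=O`: "not active" (no number reported)
compound 3 `COc1ccccc1N1CCN(C(=O)CN2C(=O)CC(C)(c3ccccc3)C2=O)CC1`: not yet measured

In a functional assay on the whole organism (strain CD-1) with Mus musculus as the target, with a stated time of 0.5 h (on this read-out higher numbers stand for an effect only at larger amounts of compound and lower numbers for an effect already at smaller amounts), compound 1 gives 300 mg/kg, whereas compound 2 is reported only as "not active" (no number reported), with no number attached. Compound 2 therefore stands without a value on this assay; it sits outside the range in which compound 1 was scored, and nothing further can be read from the pair.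

The step to compound 3 is 2-methoxyphenyl in place of 3-chlorophenyl on an amine nitrogen in a ring. No comparison of the same kind is available within the measured set, and compound 2 carries no number from which a step could be sized. On this assay the expectation is that the change does no more than keep compound 3 in the same region as compound 2, with a real chance that only a qualitative result is again reported. For compound 3 the minimum effective dose is estimated at 300 mg/kg, with a range from 100 mg/kg to 1000 mg/kg.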

Compound 3, minimum effective dose: "not active" (no number reported)
Compound 3: no number reported; no gap can be computed for the estimate.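

Compound 2 and compound 3 are both reported only as not active, without a number, so no step can be read between them. No evidence bears on this result. The compounds shown leave open how 3-chlorophenyl and 2-methoxyphenyl rank against each other on this read-out.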